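The source may report more compounds than this note shows. Statements on the series, on what has been measured and on what is new or still open speak of the compounds shown alone.

Compound 3 `CN1CC[C@H](c2ccc(Cl)cc2)[C@@H](CCC(=O)O)C1` stands highest of the three numbers in an assay on striatum with sodium-dependent dopamine transporter (Rattus norvegicus) as the target (on this read-out higher numbers stand for weaker inhibition and lower numbers for stronger inhibition), giving 1300 nM. Its nearest neighbour is compound 1 `CN1CC[C@H](c2ccc(Cl)cc2)[C@@H](C(=O)OC(C)(C)C)C1`, which gives 318 nM, and the furthest is compound 2 `CN1CC[C@H](c2ccc(Cl)cc2)[C@@H](CC(=O)N(C)C)C1`, which gives 16 nM. The change 2-(methoxycarbonyl)ethenyl in place of 2-carboxyethyl on a saturated ring carbon yields compound 4 `COC(=O)/C=C/[C@H]1CN(C)CC[C@@H]1c1ccc(Cl)cc1`. Going by the values given here, two measured steps bear on it: the step of a 4.1-fold higher number from compound 1 to compound 3 (0.61 log units; beyond the scatter) and the step of an 81-fold higher number from compound 2 to compound 3 (1.91 log units; beyond the scatter), both of which show the 2-carboxyethyl compound giving the higher number, while the step of a 20-fold lower number from compound 1 to compound 2 (1.30 log units; beyond the scatter) shows the size of gain available between esters and amides. Compound 4 is therefore expected to give a lower number, with a step of about a 13-fold lower number from compound 3 to compound 4 (1.11 log units; beyond the scatter). The estimate for compound 4 is 100 nM, within a range from 25 nM to 500 nM.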

Compound 4, inhibition constant: 53 nM
Compound 4: middle estimate off by 1.9-fold (0.28 log units), on the high side; low and high end bracket the measured number.
By their numbers in this assay, from the lowest: compound 2; then compound 4; then compound 1; then compound 3.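

In this assay, replacing 2-carboxyethyl with 2-(methoxycarbonyl)ethenyl on this saturated ring carbon gives a 25-fold lower number from compound 3 to compound 4 (1.39 log units; beyond the scatter), so the position accepts this unsaturated ester chain far better than the acid chain. The new group falls within the span of the earlier groups, with a 6.0-fold lower number from compound 1 to compound 4 (0.78 log units; beyond the scatter) but also a 3.3-fold higher number from compound 2 to compound 4 (0.52 log units; beyond the scatter). Nothing available gives a reason for these steps.

As far as these compounds go, the double bond and the methyl ester changed together, so their separate shares in the step remain open. From the compounds shown here alone, a saturated 2-(methoxycarbonyl)ethyl chain would part them, and how an amine or a longer chain would read on this carbon also stays open.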